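From cyclopropyl to oxan-4-yl on a carbonyl carbon

A few compounds are considered here, and "the series" means these few. Any claim that something is new, unique, unknown or untested is made for them only; others in the source may bear on it.

Values from a physicochemical assay for lipophilicity (on this read-out higher numbers stand for higher lipophilicity and lower numbers for lower lipophilicity), for the measured compounds:
- Compound 1 `CCC(=O)N1CC[C@H](Nc2ncnc3c2nc(-c2cnn(CC)c2C)n3C)C1` gives 0.8
- Compound 2 `CCn1ncc(-c2nc3c(N[C@H]4CCN(C(=O)C5CC5)C4)ncnc3n2C)c1C` gives 1
- Compound 3 `CCn1ncc(-c2nc3c(O[C@H]4CCN(C(=O)C5CC5)C4)ncnc3n2C)c1C` gives 1.2

Compound 2 at 1 lies within the usual scatter of both compound 1 and compound 3, so it is a sound point to start from. Compound 4 `CCn1ncc(-c2nc3c(N[C@H]4CCN(C(=O)C5CCOCC5)C4)ncnc3n2C)c1C` has not yet been measured, and it differs from compound 2 at a single place. The difference is oxan-4-yl in place of cyclopropyl on a carbonyl carbon and in words it is oxan-4-yl in place of cyclopropyl on a carbonyl carbon.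

Among the compounds with values here, only one measured step concerns this same carbonyl carbon, with cyclopropyl in place of ethyl. That step is a number 0.20 log units higher from compound 1 to compound 2 (within the scatter) and it is small. Within the data shown here, it is also only a loose guide, since no measured compound carries oxan-4-yl and the entering ring holds an oxygen that neither ethyl nor cyclopropyl has. The expected change is a number 0.20 log units lower from compound 2 to compound 4 (within the scatter) and no step beyond the scatter is foreseen, with the downward direction only a tentative call. For compound 4 the estimated value in this assay is 0.8 (expected range 0.4 to 1.2).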

Compound 4, distribution coefficient: 0.8
Compound 4: middle estimate and measured number agree at the digits printed; the range from low to high includes it.
By their numbers in this assay, from the lowest: compounds 1, 4, 2 and 3 (each within the scatter of the next, the first and the last beyond it).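

Compound 4 is the first compound shown with an oxygen in the group on this carbonyl carbon, and in this assay the swap from cyclopropyl to oxan-4-yl gives a number 0.20 log units lower from compound 2 to compound 4 (within the scatter) for a much larger group. Compared with the open ethyl group, oxan-4-yl gives no change at the digits printed from compound 1 to compound 4 (within the scatter) on the same amide carbonyl. Taken together with the earlier ethyl-to-cyclopropyl step, this means that ethyl, cyclopropyl and oxan-4-yl all lie within the scatter of one another here, so in this series this assay does not separate these three groups, even though they differ in size, in having a ring and in carrying a hydrogen-bond acceptor.

Nothing measured here speaks to why these three groups read alike. As far as these compounds go, it also remains open whether a group of a different kind on this carbonyl carbon, such as an amine or a carboxylic acid, would stay within the scatter, and whether oxan-4-yl would read the same way in the setting of compound 3.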